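This account rests on a few compounds, and the source may have more. Where it says the series, first, only, none or still open, it means among the compounds named here.

Of the compounds shown here, three sharing one core have been measured in an ADME assay on microsomes from liver (Mus musculus) for metabolic stability, read by LC-MS, with a stated time of 30 min, tested at 1 uM; on this read-out higher numbers stand for a more stable compound and lower numbers for a less stable compound. Compound 1 `Cc1ccccc1S(=O)(=O)c1ccc(CNC(=O)c2cc3cnccc3[nH]2)cc1` gives 15%, compound 2 `O=C(NCc1ccc(S(=O)(=O)c2cccc(C(F)(F)F)c2)cc1)c1cc2cnccc2[nH]1` gives 49%, and compound 3 `O=C(NCc1ccc(S(=O)(=O)c2cc(F)cc(F)c2)cc1)c1cc2cnccc2[nH]1` gives 63%. Compound 2 therefore stands second highest of the three, with compound 3 higher and compound 1 lower, and both gaps lie beyond the scatter.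

Compound 4 `O=C(NCc1ccc(S(=O)(=O)c2cccc(C(F)(F)F)c2)cc1)c1cc2ccncc2o1` keeps the 3-(trifluoromethyl)phenyl on the sulfonyl sulfur of compound 2 and changes the group on the carbonyl carbon: a group of 9 heavy atoms (7 carbon, 1 nitrogen, 1 oxygen; one five-membered aromatic ring with 1 hetero atom, one six-membered aromatic ring with 1 hetero atom) in place of a group of 9 heavy atoms (7 carbon, 2 nitrogen; one five-membered aromatic ring with 1 hetero atom, one six-membered aromatic ring with 1 hetero atom), on a carbonyl carbon. The entering group carries oxygen and has no hydrogen-bond donors.

For the measured compounds named here, all the measured steps change a different place, the group on a sulfonyl sulfur. They are a number 34 percentage points higher from compound 1 to compound 2 (beyond the scatter), a number 48 percentage points higher from compound 1 to compound 3 (beyond the scatter) and a number 14 percentage points higher from compound 2 to compound 3 (beyond the scatter), so two are large and one is modest. They show that a single swap can move the percent remaining a long way in this small set, but none of them tests the group on the carbonyl carbon. The data therefore give no direction for this change, and the best expectation is no step beyond the scatter, held with wide uncertainty. The expected step is a number 4 percentage points lower from compound 2 to compound 4 (within the scatter). For compound 4 the estimate is 45%, with an expected range from 22% to 68%.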

Compound 4, percent of the compound remaining: 64%
Estimate against measurement, compound 4: 19 percentage points below; the range from low to high includes it.
By their numbers in this assay, from the lowest: compound 1; then compound 2; then compounds 3 and 4 (each within the scatter of the next).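

The group on the carbonyl carbon can also shift the percent remaining in this assay: with the 3-(trifluoromethyl)phenyl on the sulfonyl sulfur held constant, this swap gives a number 15 percentage points higher from compound 2 to compound 4 (beyond the scatter). So the sulfonyl sulfur is not the only place in this set where one change moves the read-out beyond the scatter. The two groups have the same number of heavy atoms and the same ring sizes, but one ring nitrogen gives way to oxygen and the hydrogen-bond donor is lost; no measurement here explains why the number moves with this change.

For the compounds shown here, the step is seen with only one group on the sulfonyl sulfur, so it remains open whether the same swap would move the number in the same direction or by a similar amount with 3,5-difluorophenyl or 2-methylphenyl there. Going by these compounds, it is also open whether the oxygen itself or the missing donor hydrogen goes with the change, and a matching group with sulfur in place of that oxygen would add another comparison at this position.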